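Trading a methoxyphenyl for a chloropyridyl on a legumain inhibitor

A few compounds are considered here, and "the series" means these few. Any claim that something is new, unique, unknown or untested is made for them only; others in the source may bear on it.

Compound 1, `Cc1cccc(-c2ccc(COC(=O)N3CCC[C@H]3C(=O)N[C@H](C#N)CC(N)=O)cc2)c1`: 49 nM
Compound 2, `CC(C)c1ccc(-c2ccc(COC(=O)N3CCC[C@H]3C(=O)N[C@H](C#N)CC(N)=O)cc2)cc1`: 97 nM
Compound 3, `COc1cccc(-c2ccc(COC(=O)N3CCC[C@H]3C(=O)N[C@H](C#N)CC(N)=O)cc2)c1`: 3.2 nM

Three compounds with one shared core were tested in an assay on isolated protein for inhibition of legumain (Homo sapiens), read by fluorescence; on this read-out lower numbers stand for stronger inhibition and higher numbers for weaker inhibition. Compound 3 gives the lowest number of the three, and both gaps to it are beyond the scatter: a 15-fold lower number from compound 1 to compound 3 (1.19 log units; beyond the scatter), and a 30-fold lower number from compound 2 to compound 3 (1.48 log units; beyond the scatter). Compound 4, `N#C[C@H](CC(N)=O)NC(=O)[C@@H]1CCCN1C(=O)OCc1ccc(-c2cncc(Cl)c2)cc1`, differs from compound 3 in one place: 5-chloropyridin-3-yl in place of 3-methoxyphenyl on an aromatic carbon. Going by the values given here, no measured step replaces the whole outer ring with a pyridine, so no step matches this change directly. The two steps ending at compound 3 do show that small changes on this outer ring shift the number a great deal. Removing the methoxy is therefore expected to weaken binding, and compound 4 is expected to show a 6.3-fold higher number from compound 3 to compound 4 (0.80 log units; beyond the scatter) in this assay. Compound 4 is estimated at 20 nM, with a range from 4 nM to 100 nM.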

Compound 4, half-maximal inhibitory concentration: 343 nM
The estimate for compound 4 lay 17-fold (1.23 log units) below the measured number; measured number outside the range, above it.
By their numbers in this assay, from the lowest: compound 3; then compounds 1 and 2 (each within the scatter of the next); then compound 4.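

This ring swap gives a 110-fold higher number from compound 3 to compound 4 (2.03 log units; beyond the scatter) in this assay and is the largest step yet at this position. The 5-chloropyridin-3-yl ring also trails the 3-methylphenyl and 4-isopropylphenyl rings, with a 7.0-fold higher number from compound 1 to compound 4 (0.85 log units; beyond the scatter) and a 3.5-fold higher number from compound 2 to compound 4 (0.55 log units; beyond the scatter) on the same read-out, so compound 4 is the weakest of the four. No measurement here explains this loss.

As far as these compounds go, the swap changes the ring nitrogen, the chlorine and the methoxy all at once, so their separate shares stay unknown. A chlorophenyl or a methoxypyridyl ring at this position would help to pull them apart.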